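Swapping a Dimethoxyphenyl for Thiophene on the Ketone

A few compounds are considered here, and "the series" means these few. Any claim that something is new, unique, unknown or untested is made for them only; others in the source may bear on it.

Three compounds share one core and differ only in the ring attached to the carbonyl carbon. Compound 1 `COc1ccc(-c2cc3ccccc3nc2/C=C/C(=O)c2ccc(OC)cc2OC)cc1` gives 7990 nM in a functional assay on A549 cells (Homo sapiens) for antiproliferative activity, read by XTT assay, with a stated time of 72 h (on this read-out higher numbers stand for weaker inhibition and lower numbers for stronger inhibition), compound 2 `COc1ccc(-c2cc3ccccc3nc2/C=C/C(=O)c2c(OC)cccc2OC)cc1` gives 7410 nM, and compound 3 `COc1ccc(-c2cc3ccccc3nc2/C=C/C(=O)c2ccc(OC)c(OC)c2)cc1` gives 8860 nM. The steps of a 1.1-fold lower number from compound 1 to compound 2 (0.03 log units; within the scatter), a 1.1-fold higher number from compound 1 to compound 3 (0.04 log units; within the scatter) and a 1.2-fold higher number from compound 2 to compound 3 (0.08 log units; within the scatter) all stay within the scatter, so compound 3 cannot be told apart from the other two. Compound 4 `COc1ccc(-c2cc3ccccc3nc2/C=C/C(=O)c2cccs2)cc1` brings a different kind of change: thiophen-2-yl in place of 3,4-dimethoxyphenyl on a carbonyl carbon. For the measured compounds named here, none of the measured steps swaps the ring itself; they only move methoxy groups around a ring, and each stayed within the scatter. The expected step of a 1.1-fold lower number from compound 3 to compound 4 (0.04 log units; within the scatter) is therefore small and uncertain in direction. Compound 4 is estimated at 8000 nM, within 2500 nM to 25000 nM.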

Compound 4, half-maximal inhibitory concentration: 920 nM
Beside the measured number, compound 4's estimate is 8.7-fold (0.94 log units) above it; measured number below the stated range.
By their numbers in this assay, from the lowest: compound 4; then compounds 2, 1 and 3 (each within the scatter of the next).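

In this assay, moving methoxy groups around the phenyl ring on the carbonyl carbon changed little, but replacing that ring with thiophen-2-yl gives a 9.6-fold lower number from compound 3 to compound 4 (0.98 log units; beyond the scatter) and an 8.1-fold lower number from compound 2 to compound 4 (0.91 log units; beyond the scatter) and also an 8.7-fold lower number from compound 1 to compound 4 (0.94 log units; beyond the scatter). So the kind of ring at this position matters more here than the placement of its methoxy groups. No measurement at hand explains why.

This swap changes ring size, adds sulfur and removes both methoxy groups at once, so the compounds shown cannot say which change counts. An unsubstituted phenyl or a furan-2-yl ring on the carbonyl carbon would help separate these changes.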